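The compounds below may be only part of what the source reports. "The series", "measured", "known", "first", "only" and "open" are said of these compounds alone.

Measured in an assay on brain for binding affinity to Neuronal acetylcholine receptor; alpha4/beta2 (Rattus norvegicus), read by radioligand binding; on this read-out lower numbers stand for stronger inhibition and higher numbers for weaker inhibition:
compound 1 `Cc1ccc(OC[C@@H]2CCN2)cn1` gives 0.057 nM
compound 2 `COc1ccc(OC[C@@H]2CCN2)cn1` gives 1.3 nM
compound 3 `Cc1ccc(OC[C@H]2CCN2)cn1` gives 0.053 nM

Compounds 1 and 3 share the same atoms and bonds; (the two compounds have the same atoms and bonds and differ only in configuration as drawn: 1 of 1 stereo elements differ; a stereocentre at a saturated ring carbon is drawn S in compound 1 and R in compound 3). Going by the values given here, their values in this assay sit within the scatter of each other, so no order is read between them; this is the only pair with such a relation here, and the fact that compounds 1 and 3 differ only in the configuration as drawn is noted alongside it.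

The change from compound 1 to compound 2 is methoxy in place of methyl on an aromatic carbon. In this assay it made a 23-fold higher number from compound 1 to compound 2 (1.36 log units; beyond the scatter).

Compound 4 `COc1ccc(OC[C@H]2CCN2)cn1` has not yet been measured in this assay. Relative to compound 3 it carries methoxy in place of methyl on an aromatic carbon. The place is the same word for word as in the change from compound 1 to compound 2, so this is the same change, made on the other configuration of the shared core.

In this assay the expected step is a 23-fold higher number from compound 3 to compound 4 (1.35 log units; beyond the scatter). This rests on the measured step of a 23-fold higher number from compound 1 to compound 2 (1.36 log units; beyond the scatter) and on the value of compound 3, 0.053 nM, with the two cores otherwise giving values within the scatter of each other. Compound 4 is therefore estimated to give 1.2 nM, with a likely range from 0.4 nM to 3.5 nM.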

Compound 4, inhibition constant: 0.67 nM
For compound 4 the middle estimate is 1.8-fold (0.25 log units) above the measured one, within the range that was stated.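

In this assay, methoxy in place of methyl on an aromatic carbon gives a 13-fold higher number from compound 3 to compound 4 (1.10 log units; beyond the scatter) on the second configuration, and the step carries over from the first core with no difference that can be read: the same change on two cores in this assay, a 23-fold higher number (1.36 log units; beyond the scatter) from compound 1 to compound 2 and a 13-fold higher number (1.10 log units; beyond the scatter) from compound 3 to compound 4, 1.8-fold (0.26 log units) apart, within the scatter of two such steps. With methoxy, as with methyl, no order is read between the two configurations, here at a 1.9-fold lower number from compound 2 to compound 4 (0.29 log units; within the scatter): the fact that compounds 2 and 4 differ only in the configuration as drawn. This supports carrying this one change between these two cores, which differ only in configuration, but it does not show that the step would hold on a core with different atoms or for any other change.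

The compounds shown hold only methyl and methoxy at this place on the aromatic ring, so the effect of an amine, a chlorine atom or a longer chain such as ethoxy remains open. Also open, going by these compounds, is whether the two configurations would still give values within the scatter of each other with such groups in place.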